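This account rests on a few compounds, and the source may have more. Where it says the series, first, only, none or still open, it means among the compounds named here.

In a functional assay on HeLa cells (Homo sapiens) for cytotoxicity, read by microscopy (on this read-out lower numbers stand for higher toxicity in this test and higher numbers for lower toxicity in this test), compound 1 `CCCc1ccc(-c2cc3cn([C@H]4C[C@H](O)[C@@H](CO)O4)c(=O)nc3s2)cc1` gives 80000 nM, the highest of the three numbers measured, though its neighbours sit close: compound 2 `CCCCCCCc1ccc(-c2cc3cn([C@H]4C[C@H](O)[C@@H](CO)O4)c(=O)nc3s2)cc1` gives 50000 nM and compound 3 `CCCCCc1ccc(-c2cc3cn([C@H]4C[C@H](O)[C@@H](CO)O4)c(=O)nc3s2)cc1` gives 50000 nM. The steps among them are small, a 1.6-fold lower number from compound 1 to compound 2 (0.20 log units; within the scatter), a 1.6-fold lower number from compound 1 to compound 3 (0.20 log units; within the scatter) and no change at the digits printed from compound 2 to compound 3 (within the scatter). Compound 4 `CCCCCCCCc1cc2cn([C@H]3C[C@H](O)[C@@H](CO)O3)c(=O)nc2s1` is reached from compound 1 by octyl in place of 4-propylphenyl on an aromatic carbon. Among the measured compounds shown here, no measured step bears directly on this change: the three measured steps only lengthen or shorten the chain on the aromatic ring that here leaves altogether. With only small shifts seen so far, the number for compound 4 is expected to stay near that of compound 1, with the step of a 1.6-fold lower number from compound 1 to compound 4 (0.20 log units; within the scatter) estimated. Compound 4 is therefore estimated at 50000 nM, within 15000 nM to 100000 nM.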

Compound 4, minimum cytotoxic concentration: 20000 nM
Estimate against measurement, compound 4: 2.5-fold (0.40 log units) above; the range from low to high includes it.
By their numbers in this assay, from the lowest: compound 4; then compounds 2, 3 and 1 (each within the scatter of the next).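

Among the compounds shown here, exchanging 4-propylphenyl for octyl on the aromatic carbon next to the ring sulfur gives the first step beyond the scatter, with a 4.0-fold lower number from compound 1 to compound 4 (0.60 log units; beyond the scatter) in this assay. The earlier steps shown here, which only altered the chain on the aromatic ring in compounds 1, 2 and 3, all stayed within the scatter. No measurement here explains the larger step.

On these data alone, whether the step follows from losing the ring or from octyl itself remains open. A decyl chain or a phenyl group without any chain at this position would bear on that question.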